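The source may hold more compounds than are shown below. What is called first, only, known or untested is meant among the compounds shown, and "the series" means these compounds.

Measured so far in an in vitro functional assay on CHO/Galpha16 cells for antagonist activity at C-C chemokine receptor type 8 (Homo sapiens), read by FLIPR; a higher number here means a weaker inhibitor, a lower number a stronger inhibitor:
compound 1 `CCCC(=O)N1CCC(NS(=O)(=O)c2ccc(NC(=O)c3cccc(C)c3)c3ccccc23)CC1` — compound 1 gives 5.1 nM
compound 2 `CCCC(=O)N1CCC(NS(=O)(=O)c2ccc(NC(=O)c3ccc(F)cc3)c3ccccc23)CC1` — compound 2 gives 59.5 nM
compound 3 `CCCC(=O)N1CCC(NS(=O)(=O)c2ccc(NC(=O)c3cc(C)oc3C(F)(F)F)c3ccccc23)CC1` — compound 3 gives 46.9 nM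

Compound 3 stands second highest of the three numbers; its nearest neighbour is compound 2, a pair within the scatter (a 1.3-fold lower number from compound 2 to compound 3 (0.10 log units; within the scatter)), while compound 1 sits furthest away (a 9.2-fold higher number from compound 1 to compound 3 (0.96 log units; beyond the scatter)). Compound 4 `CCCC(=O)N1CCC(NS(=O)(=O)c2ccc(NC(=O)c3ccccn3)c3ccccc23)CC1` differs from compound 3 in one place: pyridin-2-yl in place of 5-methyl-2-(trifluoromethyl)furan-3-yl on a carbonyl carbon. Among the measured compounds shown here, no measured step brings in a six-membered aromatic ring with 1 hetero atom, so the steps that bear on it are the exchanges at the same carbonyl carbon: a 12-fold higher number from compound 1 to compound 2 (1.07 log units; beyond the scatter), a 9.2-fold higher number from compound 1 to compound 3 (0.96 log units; beyond the scatter) and a 1.3-fold lower number from compound 2 to compound 3 (0.10 log units; within the scatter). Both replacements of 3-methylphenyl moved the number upward markedly, whereas the swap between the two weaker groups stayed within the scatter. The coming step is therefore expected to be small, a 1.2-fold lower number from compound 3 to compound 4 (0.07 log units; within the scatter), with wide uncertainty. Compound 4 is estimated at 40 nM, range 10 nM to 160 nM.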

Compound 4, half-maximal inhibitory concentration: 41.7 nM
The estimate for compound 4 lay 1.0-fold (0.02 log units) below the measured number; the range from low to high includes it.
By their numbers in this assay, from the lowest: compound 1; then compounds 4, 3 and 2 (each within the scatter of the next).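

Pyridin-2-yl, the only six-membered aromatic ring with a hetero atom here, gives a 1.1-fold lower number from compound 3 to compound 4 (0.05 log units; within the scatter) and a 1.4-fold lower number from compound 2 to compound 4 (0.15 log units; within the scatter), so a drop in heavy atoms from 5-methyl-2-(trifluoromethyl)furan-3-yl to pyridin-2-yl at this carbonyl carbon, with a different ring, leaves the number within the scatter. The gap to the 3-methylphenyl group remains: an 8.2-fold higher number from compound 1 to compound 4 (0.91 log units; beyond the scatter). No measurement on hand explains this difference. Open, as far as these compounds go, is whether the methyl carries that gap: plain phenyl, 3-chlorophenyl or 3-ethylphenyl on the same carbonyl carbon would test this.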